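Removing the Acetyl Group from Compound 3

The source may hold more compounds than are shown below. What is called first, only, known or untested is meant among the compounds shown, and "the series" means these compounds.

Of the compounds shown here, three sharing one core have been measured in a functional assay on SGC-7901 cells (Homo sapiens) for inhibition, read by MTT assay, with a stated time of 72 h (on this read-out lower numbers stand for stronger inhibition and higher numbers for weaker inhibition), so far. Compound 1 (`O=C1Nc2ccccc2/C1=C\C(=O)c1cccc(Cl)c1`) gives 8400 nM here, compound 2 (`CC(C)C(=O)Nc1cccc(C(=O)/C=C2/C(=O)Nc3ccccc32)c1`) gives 8600 nM here, and compound 3 (`CC(=O)Nc1cccc(C(=O)/C=C2/C(=O)Nc3ccccc32)c1`) gives 14100 nM here. Compound 3 therefore sits level with the other two, with a 1.7-fold higher number from compound 1 to compound 3 (0.22 log units; within the scatter) and a 1.6-fold higher number from compound 2 to compound 3 (0.21 log units; within the scatter) as the steps that reach it.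

Compound 4 (`Nc1cccc(C(=O)/C=C2/C(=O)Nc3ccccc32)c1`) has hydrogen in place of acetyl on a nitrogen on an aromatic ring, which turns acetamido to amino (hydrogen in place of acetyl on a nitrogen on an aromatic ring). Going by the values given here, no measured step removes the acetyl group in this way, so the evidence is indirect. The nearest step, a 1.6-fold higher number from compound 2 to compound 3 (0.21 log units; within the scatter) in the same spot, swaps isopropyl for methyl on the carbonyl carbon. The larger swap of chloro for a whole amide group, a 1.0-fold higher number from compound 1 to compound 2 (0.01 log units; within the scatter) for example, is just as small.

No change beyond the scatter is therefore expected, and the estimated size is a 1.4-fold lower number from compound 3 to compound 4 (0.15 log units; within the scatter) in this assay for now. The expected value for compound 4 is 10000 nM within an estimated range of 4500 nM to 22000 nM in this read-out.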

Compound 4, half-maximal inhibitory concentration: 14400 nM
Beside the measured number, compound 4's estimate is 1.4-fold (0.16 log units) below it, and the stated range covers the measured number.
By their numbers in this assay, from the lowest: compounds 1, 2, 3 and 4 (each within the scatter of the next).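

In this assay, going by these compounds alone, replacing acetyl with hydrogen on the nitrogen on an aromatic ring gives the first direct reading of this change, and the free amino group stands level with acetamido (a 1.0-fold higher number from compound 3 to compound 4 (0.01 log units; within the scatter)). Amino also stays level with the (isopropylcarbonyl)amino group (a 1.7-fold higher number from compound 2 to compound 4 (0.22 log units; within the scatter)) and with chloro (a 1.7-fold higher number from compound 1 to compound 4 (0.23 log units; within the scatter)), so all four groups seen in this one spot on the shared core lie within the usual scatter of one another. Nothing available here offers an explanation for this flat result.

Going by these compounds, it remains open whether a carboxylic acid, a methoxy group or a longer chain on the amide carbonyl would stay level as well. On these data alone, whether the same flat picture would hold with changes elsewhere on the core also remains unknown.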